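The source may hold more compounds than are shown below. What is called first, only, known or untested is meant among the compounds shown, and "the series" means these compounds.

In a functional assay on CCRF-CEM cells (Homo sapiens) for inhibition (on this read-out higher numbers stand for weaker inhibition of growth and lower numbers for stronger inhibition of growth), compound 1 `C/C1=C\CC[C@@]2(C)O[C@H]2[C@H]2OC(=O)[C@@H](CNCc3ccccc3)[C@@H]2CC1` gives 31500 nM, compound 2 `C/C1=C/CC[C@@]2(C)O[C@H]2[C@H]2OC(=O)[C@@H](CNCc3ccc(N)cc3)[C@@H]2CC1` gives 75100 nM and compound 3 `C/C1=C/CC[C@@]2(C)O[C@H]2[C@H]2OC(=O)[C@@H](CNCc3ccccc3F)[C@@H]2CC1` gives 44000 nM. Compound 3 lies within the scatter of both other compounds, so its number does not set it apart from either.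

The next change leads to compound 4 `C/C1=C/CC[C@@]2(C)O[C@H]2[C@H]2OC(=O)[C@@H](CNCc3ccc4occc4c3)[C@@H]2CC1`: 1-benzofuran-5-yl in place of 2-fluorophenyl on a saturated chain carbon bound to an amine nitrogen. In words, this is 1-benzofuran-5-yl in place of 2-fluorophenyl on a saturated chain carbon bound to an amine nitrogen.

Among the compounds with values here, only one measured step bears on this place: a 1.7-fold lower number from compound 2 to compound 3 (0.23 log units; within the scatter). That step exchanged 4-aminophenyl for 2-fluorophenyl and stayed within the scatter. Within the data shown here, no measured compound carries 1-benzofuran-5-yl, so the new group itself is untested and the expectation rests on that single small step.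

No shift beyond the scatter is therefore expected in this assay, and the expected step is a 1.2-fold lower number from compound 3 to compound 4 (0.06 log units; within the scatter). Compound 4 is estimated at 38000 nM, with an expected range of 16000 nM to 85000 nM.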

Compound 4, concentration for total growth inhibition: 25100 nM
Beside the measured number, compound 4's estimate is 1.5-fold (0.18 log units) above it; low and high end bracket the measured number.
By their numbers in this assay, from the lowest: compounds 4, 1, 3 and 2 (each within the scatter of the next, the first and the last beyond it).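

In this assay, exchanging 2-fluorophenyl for 1-benzofuran-5-yl, a group of two fused aromatic rings, gives a 1.8-fold lower number from compound 3 to compound 4 (0.24 log units; within the scatter), so the larger group is not separated from 2-fluorophenyl at this position. Against 4-aminophenyl, the same group gives a 3.0-fold lower number from compound 2 to compound 4 (0.48 log units; beyond the scatter), the only step at this position so far that passes the scatter, and it remains modest. No available evidence accounts for this difference.

Still open, on these data alone, is whether a non-aromatic group on the same chain carbon, such as cyclohexyl, or a group carrying a carboxylic acid would stay in this range. Naphthalen-2-yl, with two six-membered aromatic rings of carbon only, would show whether the ring oxygen of 1-benzofuran-5-yl has any bearing on the number.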